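This account rests on a few compounds, and the source may have more. Where it says the series, first, only, none or still open, it means among the compounds named here.

Measured so far in an ADME assay for permeability, using PAMPA, in phosphate buffer, with a stated time of 18 h, tested at 25 ug/mL; on this read-out lower numbers stand for lower permeability and higher numbers for higher permeability:
compound 1 `Fc1ccc(-c2nnc(N3CCN(c4ccccn4)CC3)o2)c(F)c1`: 6.1 10^-6 cm/s
compound 2 `FC(F)(F)Oc1ccc(-c2nnc(N3CCN(c4ccccn4)CC3)o2)cc1`: 6.8 10^-6 cm/s

Only these two compounds have been measured so far. Compound 2 reads 6.8 10^-6 cm/s and stands level with compound 1 at 6.1 10^-6 cm/s, since the two values lie within the usual scatter of each other. The next compound to be tested is compound 3 `Brc1ccc(-c2nnc(N3CCN(c4ccccn4)CC3)o2)cc1`. It keeps the shared core of compound 2 but carries bromo in place of trifluoromethoxy on an aromatic carbon, para to a large group (bromo in place of trifluoromethoxy on an aromatic carbon).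

Going by the values given here, the data contain no measured pair that differs in one place, so nothing shows directly what this exchange does in this assay. The expectation therefore rests only on the two values in hand, and with so little to go on, no shift beyond the scatter is anticipated in either direction. The expected step is a 1.1-fold lower number from compound 2 to compound 3 (0.05 log units; within the scatter). For compound 3 the estimated value is 6 10^-6 cm/s, with an expected range of 3 10^-6 cm/s to 11 10^-6 cm/s.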

Compound 3, apparent permeability: 5.9 10^-6 cm/s
Estimate against measurement, compound 3: 1.0-fold (0.01 log units) above; measured number inside the range.
By their numbers in this assay, from the lowest: compounds 3, 1 and 2 (each within the scatter of the next).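

In this assay, the exchange of trifluoromethoxy, with 5 heavy atoms and 1 hydrogen-bond acceptor, for bromo, with 1 heavy atom and 0 hydrogen-bond acceptors, gives a 1.2-fold lower number from compound 2 to compound 3 (0.06 log units; within the scatter) at an aromatic carbon para to a large group. Going by these compounds alone, this is the first direct reading of a change at this position, and it shows that this difference in the group leaves the number level with that of compound 2. The wider change of 4-bromophenyl in place of 2,4-difluorophenyl gives a 1.0-fold lower number from compound 1 to compound 3 (0.01 log units; within the scatter) and likewise stays level, so compound 1, compound 2 and compound 3 form a single group in this read-out, but nothing measured on these compounds explains why the values stay together.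

The compounds shown leave open whether the number stays level when an amine, a carboxylic acid or a longer chain stands at this aromatic carbon. They also leave open whether the same holds once the shared core itself is changed, since all three compounds keep it.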